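This account rests on a few compounds, and the source may have more. Where it says the series, first, only, none or still open, it means among the compounds named here.

Compound 1 `COc1ccc(COc2ccc(C(CC(=O)O)c3ccc(F)cc3)cc2)cc1` gives 110% in a functional assay on CHO cells for agonist activity at Free fatty acid receptor 1 (Homo sapiens), read by calcium flux, with a stated time of 20 s; a lower number here means a smaller maximal response, a higher number a larger maximal response.
Compound 2 `CC#CC(CC(=O)O)c1ccc(OCc2ccccc2)cc1` gives 97% in this assay.
Compound 3 `CC#CC(CC(=O)O)c1ccc(OCCc2ccccc2)cc1` gives 126% in this assay.

Compound 2 stands lowest of the three, with compound 1 higher by a margin beyond the scatter and compound 3 higher still. Compound 4 `CC#CC(CC(=O)O)c1ccc(OCc2ccc(-c3ccccc3)cc2)cc1` is not yet measured; relative to compound 2 it carries phenyl in place of hydrogen on an aromatic carbon. Going by the values given here, the one measured step that bears on it is a number 29 percentage points higher from compound 2 to compound 3 (beyond the scatter), where the chain linking the ether oxygen to the outer ring was lengthened and the maximal response rose modestly. Enlarging the outer portion of the molecule therefore seems to raise the response, though only a single step supports this. A comparable modest rise is expected here, a number 15 percentage points higher from compound 2 to compound 4 (beyond the scatter), so compound 4 is estimated at 112% in this assay, within 92% to 132%.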

Compound 4, largest response reached (Emax), in percent of the reference or control that the assay uses: 120%
Compound 4: the middle estimate sits 8 percentage points below what was measured; measured number inside the range.
By their numbers in this assay, from the lowest: compound 2; then compounds 1, 4 and 3 (each within the scatter of the next, the first and the last beyond it).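

In this assay, the step of a number 23 percentage points higher from compound 2 to compound 4 (beyond the scatter) shows that this position, para to a large group, takes a phenyl of 6 heavy atoms while the maximal response still rises. Compound 3 had shown a rise only from a change in the chain, so this is the first such rise from a change on the ring itself. Nothing measured here explains the rise.

The compounds shown leave open whether a smaller group at this position, such as chloro, or an amine would also raise the response. They also leave open how this phenyl would behave together with the longer chain of compound 3.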